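A few compounds are considered here, and "the series" means these few. Any claim that something is new, unique, unknown or untested is made for them only; others in the source may bear on it.

Compound 1 `CCOC(=O)c1cc(/C=C/c2cccc(C(F)(F)F)c2)on1`: > 128000 nM
Compound 2 `CCOC(=O)c1cc(/C=C/c2ccccc2CC)on1`: > 128000 nM
Compound 3 `CCOC(=O)c1cc(/C=C/c2cc(OC)cc(OC)c2)on1`: > 128000 nM

All three readings come from an ADME assay on Vero cells (Chlorocebus sabaeus) for cytotoxicity, with a stated time of 72 h (a lower number here means a stronger inhibitor, a higher number a weaker inhibitor), and each is a limit of the assay, not a number. Going by the values given here, compound 1 gives no measured value, and the series so far shows only (the limit of > 128000 nM in this assay, at which 3 of the 3 values shown sit). Among the compounds with values here, no step between measured compounds is available. Compound 4 `CCOC(=O)c1cc(/C=C/c2cccc(N)c2)on1` has amino in place of trifluoromethyl on an aromatic carbon of the core of compound 1, a change counted as amino in place of trifluoromethyl on an aromatic carbon. The expected step of an at least 1.0-fold lower number from compound 1 to compound 4 (0.02 log units; that floor lies within the scatter) lies within the scatter, with no clear direction. That expectation rests on compound 1, whose > 128000 nM is a limit. Compound 4 is estimated at 120000 nM, with an expected range of 50000 nM to 128000 nM.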

Compound 4, half-maximal inhibitory concentration: > 128000 nM
Compound 4: only a limit was reported; the forecaster's own chance of this, stated with the estimate: 70%; middle value at least 1.0-fold (0.02 log units) away from the limit.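

Compound 1 and compound 4 are both limits, not numbers, in this assay, and no step can be read between them. The compounds shown leave open which change to the shared core, if any, would give a measured value: the limit of > 128000 nM in this assay, at which 4 of the 4 values shown sit.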